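Sulfonamide diamine series: working notes toward compound 4

A few compounds are considered here, and "the series" means these few. Any claim that something is new, unique, unknown or untested is made for them only; others in the source may bear on it.

Measured so far:
compound 1 `O=S(=O)(NCCNCc1ccc(-c2ccccc2)cc1)c1cc(C(F)(F)F)cc(C(F)(F)F)c1` — 2800 nM
compound 2 `O=S(=O)(NCCCNCc1ccc(Cl)c(C(F)(F)F)c1)c1cc(C(F)(F)F)cc(C(F)(F)F)c1` — 9600 nM
compound 3 `CN(CCCNS(=O)(=O)c1cc(C(F)(F)F)cc(C(F)(F)F)c1)Cc1ccccc1` — 51000 nM

All three share the sulfonamide-bearing core and were run in a functional assay on ASPC1 cells (Homo sapiens) for inhibition, read by MTT assay, with a stated time of 72 h; on this read-out lower numbers stand for stronger inhibition of growth and higher numbers for weaker inhibition of growth. Compound 3 gives the highest number of the three in this assay at 51000 nM. Its nearest neighbour is compound 2 at 9600 nM, a gap stated as beyond the scatter; the furthest is compound 1 at 2800 nM, likewise beyond the scatter. For the measured compounds named here, no two measured compounds differ in only one place, so no single-change step can be read off.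

Compound 4 `COc1ccc(CNCCCNS(=O)(=O)c2cc(C(F)(F)F)cc(C(F)(F)F)c2)cc1` is not yet measured. It differs from compound 3 in one place: (4-methoxybenzyl)amino in place of benzyl(methyl)amino on a saturated chain carbon, three bonds along the chain from a sulfonamide nitrogen. The change thus returns a hydrogen-bond donor on the chain nitrogen, as in compound 2, and swaps the substituent pattern on the benzyl ring.

In this assay the step from compound 3 to compound 4 is expected to be a decrease in number, beyond the scatter, because compound 2, the other secondary-amine compound with the same chain length, gives 9600 nM. The expected step is a 4.3-fold lower number from compound 3 to compound 4 (0.63 log units; beyond the scatter). Compound 4 is estimated at 12000 nM, with a range from 4000 nM to 35000 nM.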

Compound 4, concentration for 50% growth inhibition: 2800 nM
Compound 4: middle estimate off by 4.3-fold (0.63 log units), on the high side; the whole stated range lies above it.
By their numbers in this assay, from the lowest: compounds 1 and 4 (each within the scatter of the next); then compound 2; then compound 3.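

In this assay, the saturated chain carbon three bonds along the chain from a sulfonamide nitrogen now has its first readable step: (4-methoxybenzyl)amino in place of benzyl(methyl)amino gives an 18-fold lower number from compound 3 to compound 4 (1.26 log units; beyond the scatter) and counts as large. With the rest of the structure held, 4-methoxyphenyl in place of 4-chloro-3-(trifluoromethyl)phenyl on a saturated chain carbon bound to an amine nitrogen gives a 3.4-fold lower number from compound 2 to compound 4 (0.54 log units; beyond the scatter), a modest step, so the aromatic group alone moves the number beyond the scatter. The large step joins two changes, the loss of the methyl group and the gain of the methoxy group, and no measurement at hand gives a reason for either step.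

The compounds shown do not separate those two changes, and the (4-methoxybenzyl)(methyl)amino group or the unsubstituted benzylamino group on the same chain would be needed to apportion the large step. Also open, on these data alone, is whether the 4-methoxyphenyl result carries over to a butyl chain between the sulfonamide nitrogen and the amine nitrogen.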